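Dropping the Methoxy Group: An Expectation for Compound 4

The source may report more compounds than this note shows. Statements on the series, on what has been measured and on what is new or still open speak of the compounds shown alone.

Of the compounds shown here, three sharing one core have been tested in a functional assay on M14 cells (Homo sapiens) for inhibition, read by sulforhodamine B assay, with a stated time of 48 h; on this read-out lower numbers stand for stronger inhibition of growth and higher numbers for weaker inhibition of growth. Compound 1 `COc1ccc(-c2[nH]c3ccc(OC)cc3c2/C=C(\C#N)S(=O)(=O)c2ccccc2)cc1` gives 500 nM. Compound 2 `CC(=O)/C(=C\c1c(-c2ccccc2)[nH]c2ccccc12)S(=O)(=O)c1ccccc1` gives 521 nM. Compound 3 `COc1ccc(-c2[nH]c3ccccc3c2/C=C(\C#N)S(=O)(=O)c2ccccc2)cc1` gives 383 nM; this is the smallest number of the three, yet its gaps to compound 1 and to compound 2 both lie within the scatter, so the three cannot be ranked. Compound 4 `N#C/C(=C\c1c(-c2ccccc2)[nH]c2ccccc12)S(=O)(=O)c1ccccc1` differs from compound 3 in one place: hydrogen in place of methoxy on an aromatic carbon. Going by the values given here, one measured step bears on this change, a 1.3-fold lower number from compound 1 to compound 3 (0.12 log units; within the scatter), which stayed within the scatter. The expected step of a 1.1-fold lower number from compound 3 to compound 4 (0.04 log units; within the scatter) is therefore none beyond the scatter in this assay. Compound 4 is estimated at 350 nM, with a range from 150 nM to 800 nM.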

Compound 4, concentration for 50% growth inhibition: 3800 nM
The estimate for compound 4 lay 11-fold (1.04 log units) below the measured number; measured number outside the range, above it.
By their numbers in this assay, from the lowest: compounds 3, 1 and 2 (each within the scatter of the next); then compound 4.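

Hydrogen in place of methoxy on the 4-methoxyphenyl group matters far more than the same swap elsewhere on the shared core: that earlier swap gave a 1.3-fold lower number from compound 1 to compound 3 (0.12 log units; within the scatter), whereas this one gives a 9.9-fold higher number from compound 3 to compound 4 (1.00 log units; beyond the scatter). With phenyl present in both, cyano in place of acetyl gives a 7.3-fold higher number from compound 2 to compound 4 (0.86 log units; beyond the scatter), so phenyl alone does not bring a high number. No measurement available here explains these steps.

Going by these compounds, whether a hydroxyl, a fluorine or an ethoxy in place of that methoxy would keep the number low remains open. So does whether a methoxy there would change the number when acetyl replaces cyano.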